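Tert-butyl in place of phenyl: working notes on the series

The source may hold more compounds than are shown below. What is called first, only, known or untested is meant among the compounds shown, and "the series" means these compounds.

Of the compounds shown here, three on the shared core have been read so far. In a functional assay on THP-1 cells (Homo sapiens) for inhibition, read by ELISA, with stated times of 2 h and 48 h (a higher number here means a weaker inhibitor, a lower number a stronger inhibitor), compound 1 `[O-]/[N+](=C\c1cn(-c2ccc(Cl)cc2)nn1)c1ccccc1` gives > 20000 nM, which is a limit of the assay and not a number. Compound 2 `CCCCCCCCCCn1cc(/C=[N+](\[O-])c2ccccc2)nn1` gives 9900 nM. Compound 3 `[O-]/[N+](=C\c1cn(CCC(F)(F)C(F)(F)C(F)(F)C(F)(F)C(F)(F)C(F)(F)C(F)(F)C(F)(F)F)nn1)c1ccccc1` gives 11700 nM, within the scatter of the reading for compound 2, so these two cannot be ranked in this assay.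

Compound 4 `CC(C)(C)/[N+]([O-])=C/c1cn(CCC(F)(F)C(F)(F)C(F)(F)C(F)(F)C(F)(F)C(F)(F)C(F)(F)C(F)(F)F)nn1` keeps the rest of compound 3 and carries tert-butyl in place of phenyl on a double-bonded nitrogen. Within the data shown here, no measured pair isolates this change, so the size of the step has no direct precedent. Among the measured compounds shown here, the only anchor is compound 3 at 11700 nM, and no direction is favoured from it. The expected result, a 1.0-fold higher number from compound 3 to compound 4 (0.01 log units; within the scatter), is a change that stays within the scatter, though the uncertainty is wide. In this assay compound 4 is estimated at 12000 nM, with an expected range of 5000 nM to 27000 nM.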

Compound 4, half-maximal inhibitory concentration: 15000 nM
Beside the measured number, compound 4's estimate is 1.3-fold (0.10 log units) below it, within the range that was stated.
By their numbers in this assay, from the lowest: compounds 2, 3 and 4 (each within the scatter of the next). At a limit, above all of these: compound 1.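

In this assay, among these compounds, the first step that isolates one change is a 1.3-fold higher number from compound 3 to compound 4 (0.11 log units; within the scatter) and it stays within the scatter. On a double-bonded nitrogen, tert-butyl in place of phenyl removes the six-membered aromatic ring and leaves fewer heavy atoms, yet compound 4 cannot be ranked against compound 3. For this one pair, an aromatic ring at this position is not needed to keep a reading of this size.

As far as these compounds go, the change has been read only with the fluorinated chain of compound 3, so its effect alongside the decyl chain of compound 2 stays open, as does how a methyl group or a ring bearing an amine would read at this position. Compound 1 gives a limit of the assay and not a number, so no step can be read from it: the limit of > 20000 nM in this assay, at which 1 of the 4 values shown sits.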